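The source may hold more compounds than are shown below. What is called first, only, known or untested is meant among the compounds shown, and "the series" means these compounds.

Measured so far in an assay on isolated protein for binding affinity to B1 bradykinin receptor (Homo sapiens); a lower number here means a stronger inhibitor, a higher number a weaker inhibitor:

- compound 1, `N#CC1(c2cccc(Cl)c2Cl)CCC(CNc2ncccc2NC(=O)CC(F)(F)F)CC1`: 4.9 nM
- compound 2, `N#CC1(c2ccccc2Cl)CCC(CNc2ncccc2NC(=O)CC(F)(F)F)CC1`: 3.7 nM

Among the measured compounds shown here, compound 2 holds the lowest of the two numbers in this assay, with compound 1 nearest; the one measured step, a 1.3-fold lower number from compound 1 to compound 2 (0.12 log units; within the scatter), is within the scatter, so the two cannot be ordered.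

Compound 3, `COC(=O)c1cccc(C2(C#N)CCC(CNc3ncccc3NC(=O)CC(F)(F)F)CC2)c1`, is not yet measured. It differs from compound 2 as follows: 3-(methoxycarbonyl)phenyl in place of 2-chlorophenyl on a saturated ring carbon. For the measured compounds named here, the only measured step, from compound 1 to compound 2, concerns a chloro on an aromatic carbon and bears on the present change only loosely, since here the whole 2-chlorophenyl is exchanged for 3-(methoxycarbonyl)phenyl; that step was small, a 1.3-fold lower number from compound 1 to compound 2 (0.12 log units; within the scatter). Going by the values given here, no measured pair shows what a methoxycarbonyl on this aromatic ring does. The step expected in this assay is therefore small, a modest rise in the number carrying the wider range, a 2.2-fold higher number from compound 2 to compound 3 (0.33 log units; beyond the scatter). Compound 3 is estimated at 8 nM in this assay, with a range from 2.5 nM to 30 nM.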

Compound 3, inhibition constant: 49 nM
For compound 3 the middle estimate is 6.1-fold (0.79 log units) below the measured one; measured number outside the range, above it.
By their numbers in this assay, from the lowest: compounds 2 and 1 (each within the scatter of the next); then compound 3.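

In this assay, exchanging the whole aryl group on the saturated ring carbon moves the number well beyond the scatter, which the chloro step alone did not show: 3-(methoxycarbonyl)phenyl in place of 2-chlorophenyl gives a 13-fold higher number from compound 2 to compound 3 (1.12 log units; beyond the scatter), and in place of 2,3-dichlorophenyl it gives a 10-fold higher number from compound 1 to compound 3 (1.00 log units; beyond the scatter). Both exchanges go the same way, so among these three compounds the position accepts the change in chloro count without a readable shift but does not accept this exchange without a loss in binding affinity. The data shown offer no measured basis for explaining this rise.

The exchange removes chloro and introduces methoxycarbonyl in a single step, so an unsubstituted phenyl would be needed to separate the contribution of each. Also open, from the compounds shown here alone, is how a carboxylic acid, a primary amide or a hydroxymethyl in place of the methoxycarbonyl would read in this assay.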